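Chain homologation on the shared core: ethyl toward propyl

This account rests on a few compounds, and the source may have more. Where it says the series, first, only, none or still open, it means among the compounds named here.

The shared core carries a short chain on an aromatic nitrogen, and two members have been measured in a functional assay for antagonist activity at 5-hydroxytryptamine receptor 4 (Cavia porcellus); on this read-out higher numbers stand for higher potency (the scale is a negative logarithm) and lower numbers for lower potency. Compound 1 `CN1CCN(CCNC(=O)n2c(=O)n(C)c3ccccc32)CC1` bears a methyl there; in this assay compound 1 gives < 6, which is a limit of the assay and not a number. Compound 2 `CCn1c(=O)n(C(=O)NCCN2CCN(C)CC2)c2ccccc21` extends the chain to ethyl, and in this assay compound 2 gives 6.79. Replacing methyl by ethyl gave a number at least 0.79 log units higher from compound 1 to compound 2 (beyond the scatter); the size of that step is bounded only on one side because of the limit of < 6 in this assay, at which 1 of the 2 values shown sits. Going by the values given here, compound 2 therefore stands as the only numerical value.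

Compound 3 `CCCn1c(=O)n(C(=O)NCCN2CCN(C)CC2)c2ccccc21` continues the same direction: methyl in place of hydrogen on a saturated chain carbon, two bonds along the chain from an aromatic nitrogen. Among the compounds with values here, only the step from compound 1 to compound 2 bears on it, and it was at least modest, but it began from a limit, so how much further a second methyl carries is open. A smaller gain, or none beyond the scatter, is the expectation, worded as a number 0.21 log units higher from compound 2 to compound 3 (within the scatter). Compound 3 is thus estimated at 7, spanning 6.4 to 7.6.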

Compound 3, negative logarithm of the antagonist equilibrium constant: < 6
Compound 3: only a limit was reported; the forecaster's own chance of this, stated with the estimate: 5%; middle value at least 1.00 log units from the limit.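

The chain on the aromatic nitrogen does not reward added length in one direction: in this assay, going from ethyl to propyl gave a number at least 0.79 log units lower from compound 2 to compound 3 (beyond the scatter), which runs against a number at least 0.79 log units higher from compound 1 to compound 2 (beyond the scatter). Among these three compounds, ethyl is the only chain that returns a number, while methyl and propyl both end at a limit, so a single added methyl at this place is enough to take the read-out from a measured value to a limit. The step from compound 1 to compound 3 cannot be read, and the two compounds cannot be ranked against each other: the limit of < 6 in this assay, at which 2 of the 3 values shown sit.

Going by these compounds, how far compound 1 and compound 3 each lie past that limit stays open, so both readable steps are bounded on one side only. Also open, on these data alone, is whether the loss follows the length of the chain or its straight shape, a question that an isopropyl group, a cyclopropyl group or a longer chain such as butyl at the same place would help to settle.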